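The compounds below may be only part of what the source reports. "The series", "measured", "known", "first", "only" and "open" are said of these compounds alone.

Compound 1 `O=c1nc2c(cn1Cc1ccccc1)ncn2Cc1ccccc1` reaches in a functional assay on K562 cells (Homo sapiens), read by thymidine incorporation, with a stated time of 5 h (a higher number here means a weaker inhibitor, a lower number a stronger inhibitor), only a limit, > 10 ug/mL. Going by the values given here, compound 2 `O=C1Nc2c(ncn2Cc2ccccc2)C(C#Cc2ccccc2)N1Cc1ccccc1` carries a 2-phenylethynyl group and in this assay gives 1.4 ug/mL, the only actual number among the values shown. The other value is the limit (the limit of > 10 ug/mL in this assay, at which 1 of the 2 values shown sits), so compound 2 stands alone on the numbers and no ordering within the set can be drawn. Compound 3 `O=C1Nc2c(ncn2Cc2ccccc2)C(C#CC2CC2)N1Cc1ccccc1` differs from compound 2 by cyclopropyl in place of phenyl on a triple-bonded carbon. Among the compounds with values here, no step between two measured compounds covers a change of this kind, so the direction rests on expectation alone: a modest move toward weaker inhibition is expected, possibly not beyond the scatter of repeated measurements. Compound 3 is accordingly estimated at 3 ug/mL in this assay, with a range from 1 ug/mL to 10 ug/mL. The expected step of a 2.1-fold higher number from compound 2 to compound 3 (0.33 log units; beyond the scatter) is small, and a limit reading cannot be excluded.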

Compound 3, half-maximal inhibitory concentration: 1.6 ug/mL
Compound 3: the middle estimate sits 1.9-fold (0.27 log units) above what was measured; the measured number falls inside the stated range.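

In this assay, the first step read at this place is a 1.1-fold higher number from compound 2 to compound 3 (0.06 log units; within the scatter), so compound 2 and compound 3 stand level. On this triple-bonded carbon, an aromatic phenyl of 6 heavy atoms and a non-aromatic cyclopropyl of 3 heavy atoms therefore give readings that cannot be told apart, at least for this pair. No measurement at hand gives a reason for this result.

On these data alone, whether a ring is needed on the triple-bonded carbon at all remains open, and a straight butyl chain, a dimethylamino group or a carboxylic acid there would each bear on that question. As far as these compounds go, with a single step at this place, it is also open whether larger groups, such as naphthyl, would hold the reading in this assay.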